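Fluoro for Chloro on the Shared Core

The source may report more compounds than this note shows. Statements on the series, on what has been measured and on what is new or still open speak of the compounds shown alone.

Measured so far:
Compound 1 `c1ccc(-c2nnco2)cc1`: in an assay (Populus sieboldii x Populus grandidentata) for inhibition of Trans-cinnamate 4-monooxygenase (Populus kitakamiensis), with a stated time of 60 min (on this read-out lower numbers stand for stronger inhibition and higher numbers for weaker inhibition), compound 1 gives > 100000 nM, a limit of the measurement.
Compound 2 `Sc1nnc(-c2ccccc2Cl)o1`: in this assay compound 2 gives 680 nM.

Compound 1 sits at the limit of > 100000 nM in this assay, at which 1 of the 2 values shown sits. Among the measured compounds shown here, compound 2 therefore supplies the only numerical reading among the measured results. Compound 3 `Fc1ccccc1-c1nnc(S)o1` differs from compound 2 by fluoro in place of chloro on an aromatic carbon. For the measured compounds named here, no step between measured compounds gauges such a swap, so only a small shift in this assay is expected, within or just beyond the scatter toward weaker inhibition, with a step of a 1.8-fold higher number from compound 2 to compound 3 (0.25 log units; within the scatter) estimated. Compound 3 is expected to give 1200 nM, with a range from 400 nM to 4000 nM.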

Compound 3, half-maximal inhibitory concentration: 190 nM
The estimate for compound 3 lay 6.3-fold (0.80 log units) above the measured number; the measured number lies below the stated range.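

At this position, on an aromatic carbon ortho to a group of 6 heavy atoms, the swap of chloro for fluoro gives a 3.6-fold lower number from compound 2 to compound 3 (0.55 log units; beyond the scatter) in this assay, the first step measured here. The position is therefore not indifferent to which halogen it carries, and in this one pair fluoro gives the stronger inhibition. Nothing measured in the data shown accounts for this step.

From the compounds shown here alone, how a methyl or methoxy group on that carbon would read in this assay remains open. So does whether the same swap on another carbon of the ring would give a step of similar size.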